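Adding a Fluorobenzyl Group to a Spare Amide Nitrogen

A few compounds are considered here, and "the series" means these few. Any claim that something is new, unique, unknown or untested is made for them only; others in the source may bear on it.

Of the compounds shown here, three have been measured in an ADME assay on MDCK cells (Canis lupus familiaris) for cytotoxicity, read by microscopy, with a stated time of 72 h; on this read-out lower numbers stand for higher toxicity in this test and higher numbers for lower toxicity in this test. Compound 1 `COC(=O)C[C@H](NC(=O)OC(C)(C)C)C(=O)N(Cc1ccc(F)cc1)C1(C(=O)NCc2ccccc2)CCN(c2ccccc2)CC1` gives 20000 nM. Compound 2 `COC(=O)C[C@H](NC(=O)OC(C)(C)C)C(=O)N(Cc1ccc(F)cc1)C1(C(=O)NC(C)(C)C)CCN(Cc2ccccc2)CC1` gives 80000 nM. Compound 3 `COC(=O)C[C@H](NC(=O)OC(C)(C)C)C(=O)NC1(C(=O)NCc2ccccc2)CCN(Cc2ccccc2)CC1` gives 100000 nM, the highest number of the three. The number for compound 2 lies within the usual scatter of that of compound 3, so the two cannot be told apart, whereas the number for compound 1 lies beyond the scatter, so compound 3 is clearly less toxic than compound 1 in this assay.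

Compound 4 `COC(=O)C[C@H](NC(=O)OC(C)(C)C)C(=O)N(Cc1cccc(F)c1)C1(C(=O)NCc2ccccc2)CCN(Cc2ccccc2)CC1` has not yet been measured. It differs from compound 3 in one place: 3-fluorobenzyl in place of hydrogen on an amide-type nitrogen. Within the data shown here, no pair of measured compounds differs in exactly this way, so the size of the step cannot be read off directly. Still, both compound 1 with 20000 nM and compound 2 with 80000 nM carry a fluorobenzyl group on that same amide nitrogen, and both sit at or below the number for compound 3. The step from compound 3 to compound 4 is therefore expected to be a move toward a lower number, roughly a 2.0-fold lower number from compound 3 to compound 4 (0.30 log units; within the scatter). Compound 4 is expected to give about 50000 nM in this assay, with a likely range from 20000 nM to 100000 nM.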

Compound 4, minimum cytotoxic concentration: 47000 nM
The estimate for compound 4 lay 1.1-fold (0.03 log units) above the measured number; low and high end bracket the measured number.
By their numbers in this assay, from the lowest: compound 1; then compounds 4, 2 and 3 (each within the scatter of the next, the first and the last beyond it).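

Among these compounds, this step gives the first direct reading of this position, as compound 3 and compound 4 differ in one place only. In this assay, placing 3-fluorobenzyl on the amide-type nitrogen in place of hydrogen gives a 2.1-fold lower number from compound 3 to compound 4 (0.33 log units; beyond the scatter) and so ties a modest rise in toxicity in this test to that single change, which compound 1 and compound 2 could not do since each also differs from compound 3 elsewhere. No measurement shown here explains why the number falls with this change.

The compounds shown leave open whether the step belongs to the fluorine, to the aromatic ring, or to the presence of any group on this nitrogen; a plain benzyl group, a methyl group or a longer chain such as butyl at the same place would bear on that question. A single pair also cannot show whether 3-fluorobenzyl would shift the number by a similar amount when the other parts of the molecule are changed.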